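A few compounds are considered here, and "the series" means these few. Any claim that something is new, unique, unknown or untested is made for them only; others in the source may bear on it.

Compound 1, `CSc1ccc(CSc2nc(-c3ccc(Br)cc3)c(-c3ccncc3)[nH]2)cc1`, gives 2400 nM in a functional assay (Homo sapiens) for inhibition; on this read-out lower numbers stand for stronger inhibition and higher numbers for weaker inhibition. Compound 2, `C[S+]([O-])c1ccc(CSc2nc(-c3ccc(Br)cc3)c(-c3ccncc3)[nH]2)cc1`, gives 820 nM in this assay. Compound 3, `CSc1ccc(O)c(CSc2nc(-c3ccc(F)cc3)c(-c3ccncc3)[nH]2)c1`, gives 740 nM in this assay.

Compound 1 and compound 2 differ in one place only: a group of 3 heavy atoms (1 carbon, 1 oxygen, 1 sulfur; no ring) in place of a group of 2 heavy atoms (1 carbon, 1 sulfur; no ring), on an aromatic carbon This change made a 2.9-fold lower number from compound 1 to compound 2 (0.47 log units; beyond the scatter). Compound 3 sits on a different core; how its core differs from the core of compound 1 is not broken down here. Its value is within the scatter of compound 2 and beyond the scatter of compound 1.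

Compound 4, `C[S+]([O-])c1ccc(O)c(CSc2nc(-c3ccc(F)cc3)c(-c3ccncc3)[nH]2)c1`, has not yet been measured. Going by the values given here, it differs from compound 3 in one place: a group of 3 heavy atoms (1 carbon, 1 oxygen, 1 sulfur; no ring) in place of a group of 2 heavy atoms (1 carbon, 1 sulfur; no ring), on an aromatic carbon This is the same kind of change as the one from compound 1 to compound 2, not the same change: in compound 2 the entering group sits para to a large group, whereas in compound 4 it sits meta to a large group and para to a hydroxy group, on another core. The step is expected to be a 2.1-fold lower number from compound 3 to compound 4 (0.33 log units; beyond the scatter), somewhat smaller than the earlier one, because the same change on the first core made a 2.9-fold lower number from compound 1 to compound 2 (0.47 log units; beyond the scatter) and the surroundings of the place now differ. Compound 4 is therefore estimated at 350 nM in this assay, likely between 120 nM and 1100 nM.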

Compound 4, half-maximal inhibitory concentration: 1000 nM
Compound 4: the middle estimate sits 2.9-fold (0.46 log units) below what was measured; measured number inside the range.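

In this assay, the change on the core of compound 3 gave a 1.4-fold higher number from compound 3 to compound 4 (0.13 log units; within the scatter), so on this core replacing methylsulfanyl with the group that carries one extra oxygen has no effect that stands clear of the usual spread of repeat measurements. Going by these compounds alone, the lower number seen on the first core therefore did not carry over, and the two results truly differ: the same change on two cores in this assay, a 2.9-fold lower number (0.47 log units; beyond the scatter) from compound 1 to compound 2 and a 1.4-fold higher number (0.13 log units; within the scatter) from compound 3 to compound 4, 4.0-fold (0.60 log units) apart, beyond the scatter of two such steps With only one pair on each core, this shows that the step cannot simply be assumed to transfer, but it does not show which difference between the cores is responsible, for instance the hydroxy group para to the place in compound 4.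

Still open, on these data alone, is how the change would read on the core of compound 3 with a methoxy group or a plain hydrogen in place of that hydroxy group. Also open, as far as these compounds go, is how a methylsulfonyl group or an amine at the same place would read on each core.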